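The source may report more compounds than this note shows. Statements on the series, on what has been measured and on what is new or still open speak of the compounds shown alone.

The measured compounds:

Compound 1 `C/C(=N\Nc1nc(-c2ccc(C)cc2)cs1)c1sc(C)nc1C` — in a toxicity assay on THP-1 cells (Homo sapiens) for cytotoxicity, read by MTT assay (a lower number here means a stronger inhibitor of growth, a higher number a weaker inhibitor of growth), compound 1 gives only a limit, > 100 ug/mL.
Compound 2 `C/C(=N\Nc1nc(-c2ccc(F)cc2)cs1)c1sc(-c2ccccc2)nc1C` — in this assay compound 2 gives only a limit, > 100 ug/mL.
Compound 3 `C/C(=N\Nc1nc(-c2ccc(Cl)cc2)cs1)c1sc(-c2ccccc2)nc1C` — in this assay compound 3 gives only a limit, > 100 ug/mL.

Compound 3 thus stands where every value shown stands: at the limit of this assay, with no number beneath it. Among the measured compounds shown here, the one step among the measured compounds, a step that the two limits leave unreadable from compound 2 to compound 3, cannot be sized, since both of its ends are limits. Compound 4 `C/C(=N\Nc1nc(-c2ccc(C)cc2)cs1)c1sc(-c2ccccc2)nc1C` differs from compound 3 by methyl in place of chloro on an aromatic carbon. For the measured compounds named here, no measured step bears directly on this change; the only guide is the limit of > 100 ug/mL in this assay, at which 3 of the 3 values shown sit, which holds for all three measured compounds whatever group sits on that ring. The change is therefore expected to make no step beyond the scatter, and compound 4 is expected to give 150 ug/mL, between 60 ug/mL and 400 ug/mL. The step that this estimate means, a step that the limit leaves unreadable from compound 3 to compound 4, is expected to lie within the scatter, most likely ending again at a limit.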

Compound 4, concentration for 50% growth inhibition: > 100 ug/mL
Compound 4 was reported as a limit; the forecaster's own chance of this, stated with the estimate: 85%; the middle value is on the limit's open side.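

In this assay compound 4 gives only a limit, > 100 ug/mL. Among the compounds shown here, compound 1, compound 2 and compound 3 also give only limits, so no step from any of them to compound 4 can be read. The compounds shown leave open whether they differ from one another in growth inhibition at all: the limit of > 100 ug/mL in this assay, at which 4 of the 4 values shown sit.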